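Amino for ethoxy on compound 2

This account rests on a few compounds, and the source may have more. Where it says the series, first, only, none or still open, it means among the compounds named here.

Compound 2 `CCCCCCCc1[nH]c2ccccc2c(=O)c1C(=O)OCC` stands level with its two measured relatives in a physicochemical assay for solubility, read by HPLC, at pH 7.4; on this read-out higher numbers stand for higher solubility and lower numbers for lower solubility: compound 2 gives 5000 nM, compound 1 `CCCCCCCc1cc(OC)c2ccccc2n1` gives 5000 nM, and compound 3 `CCCCCCCc1[nH]c2ccc([N+](=O)[O-])cc2c(=O)c1C(=O)OCC` gives 5000 nM. Compound 4 `CCCCCCCc1[nH]c2ccccc2c(=O)c1C(N)=O` has amino in place of ethoxy on a carbonyl carbon. The one measured step among these compounds, nitro in place of hydrogen on an aromatic carbon, shows no change at the digits printed from compound 2 to compound 3 (within the scatter). Going by the values given here, that step changes a different place, so it bears only loosely, and no measured step alters the ethoxy group. No shift beyond the scatter is therefore expected in this assay, in either direction, and the estimated step is no change at the digits printed from compound 2 to compound 4 (within the scatter). Compound 4 is expected at 5000 nM, within an estimated range of 2500 nM to 8000 nM.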

Compound 4, solubility: 5000 nM
For compound 4 middle estimate and measured number coincide at the digits printed, within the range that was stated.
By their numbers in this assay, from the lowest: compounds 1, 2, 3 and 4 (each within the scatter of the next).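

In this assay, amino in place of ethoxy on a carbonyl carbon gives no change at the digits printed from compound 2 to compound 4 (within the scatter) and this is the only step shown at this position, as the nitro step lay at a different place. Ethoxycarbonyl to carbamoyl swaps a larger group bearing a hydrogen-bond acceptor for a smaller one bearing a hydrogen-bond donor, and the read-out stays level in this one comparison. No measurement is available that accounts for this result. Going by these compounds, whether a carboxylic acid or a dimethylamino group on this carbonyl carbon would also stay level remains open. So does the effect of a shorter chain in place of the chain on compound 4.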